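The source may hold more compounds than are shown below. What is called first, only, known or untested is meant among the compounds shown, and "the series" means these compounds.

Compound 2 `CC/N=C(/NC#N)NCCCn1nc(-c2ccccc2)ccc1=O` serves as the point of reference in this set. In a functional assay on the whole organism with Rattus norvegicus as the target, at a dose of 100 mg/kg (a higher number here means more inhibition at the dose given (going by the name of the read-out), a lower number less inhibition), compound 2 gives 62.9%. Compound 1 `C/N=C(/NC#N)NCCCn1nc(-c2ccccc2)ccc1=O` differs from it in a single place, (hydrogen in place of methyl on a saturated chain carbon bound to a double-bonded nitrogen). In this assay compound 1 gives 40.5%, which corresponds to a step of a number 22.4 percentage points lower from compound 2 to compound 1 (beyond the scatter).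

Compound 3 `CC/N=C(/NC#N)NCCCCn1nc(-c2ccccc2)c(C)cc1=O` carries a different core; the difference between the core of compound 3 and that of compound 2 is not broken down here. In this assay compound 3 gives 38.8%. Its number lies within the usual spread of that of compound 1 and is lower than that of compound 2.

Compound 4 `C/N=C(/NC#N)NCCCCn1nc(-c2ccccc2)c(C)cc1=O` stands to compound 3 as compound 1 stands to compound 2: the change is hydrogen in place of methyl on a saturated chain carbon bound to a double-bonded nitrogen, the same change at the same kind of place. Since compound 3 already sits in the lower part of the range, the step is expected to be somewhat smaller, namely a number 16.8 percentage points lower from compound 3 to compound 4 (beyond the scatter). This expectation rests on the measured step in the same direction, a number 22.4 percentage points lower from compound 2 to compound 1 (beyond the scatter), and on the fact that compound 3 starts from 38.8%, which leaves less room for a fall of the same size. The range is kept wide, as a single-dose whole-organism read-out scatters considerably.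

Compound 4 is therefore estimated to give 22% in this assay, with a plausible range from 6% to 40%.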

Compound 4, a percentage reported as inhibition, in the whole organism at one dose (the size of the read-out at that dose, not a potency): 46.4%
Compound 4: middle estimate off by 24.4 percentage points, on the low side, outside the stated range (above it).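

On the core of compound 3, the change from ethyl to methyl gives a number 7.6 percentage points higher from compound 3 to compound 4 (within the scatter), so the fall seen on the core of compound 2 does not recur in this assay. Set side by side, the two steps disagree, and the effect of this change measured on one core cannot be carried over to the other in this series: the same change on two cores in this assay, a number 22.4 percentage points lower (beyond the scatter) from compound 2 to compound 1 and a number 7.6 percentage points higher (within the scatter) from compound 3 to compound 4, 30 percentage points apart, beyond the scatter of two such steps. Within the data shown here, this does not show which of the differences between the two cores lies behind the disagreement, and with only one pair per core, each read at a single dose in the whole organism, it gives no rule for how the change behaves on any further core.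

The compounds shown leave open how a propyl or a benzyl group in place of the ethyl would read on either core, and so whether the chain on this nitrogen has any consistent trend beyond the single step from ethyl to methyl. They also leave open how the same change would read on a third core, or at a dose other than the one used here.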